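A few compounds are considered here, and "the series" means these few. Any claim that something is new, unique, unknown or untested is made for them only; others in the source may bear on it.

Among the compounds with values here, in a physicochemical assay for solubility, read by HPLC (a lower number here means a less soluble compound, a higher number a more soluble compound), compound 2 `O=C(c1ccc(Cl)cc1)N1CCN(c2nc(=O)c3cc(C(F)(F)F)cc([N+](=O)[O-])c3s2)CC1` gives 5.19 ug/mL, the higher of the two numbers measured so far, while compound 1 `O=C(CC1CCCCC1)N1CCN(c2nc(=O)c3cc(C(F)(F)F)cc([N+](=O)[O-])c3s2)CC1` gives 0.12 ug/mL. Compound 3 `CC(C)(C)C1CCC(C(=O)N2CCN(c3nc(=O)c4cc(C(F)(F)F)cc([N+](=O)[O-])c4s3)CC2)CC1` is compound 2 changed in one place: 4-(tert-butyl)cyclohexyl in place of 4-chlorophenyl on a carbonyl carbon. Within the data shown here, one measured step bears on this change, a 43-fold higher number from compound 1 to compound 2 (1.64 log units; beyond the scatter), where a six-membered non-aromatic ring of carbon only gave way to an aromatic one. Compound 3 brings back a six-membered non-aromatic ring of carbon only, so a step of roughly that size in the opposite direction is expected, a 43-fold lower number from compound 2 to compound 3 (1.64 log units; beyond the scatter). Compound 3 is estimated at 0.12 ug/mL, with a range from 0.02 ug/mL to 0.7 ug/mL.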

Compound 3, solubility: < 0.1 ug/mL
Compound 3 was reported as a limit (the forecaster's own chance of this, stated with the estimate: 15%); at least 1.2-fold (0.07 log units) between middle value and limit.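

In this assay compound 3 gives < 0.1 ug/mL, which is a limit and not a number. With a second non-aromatic ring of carbon on the carbonyl carbon, the 4-chlorophenyl compound again stands clear, an at least 51-fold lower number from compound 2 to compound 3 (1.71 log units; beyond the scatter), so the earlier gap was not confined to cyclohexylmethyl. The other comparison, an at least 1.2-fold lower number from compound 1 to compound 3 (0.07 log units; that floor lies within the scatter), does not place these two non-aromatic compounds in any order.

Still open, as far as these compounds go, is whether the higher number goes with the aromatic ring itself or with its chlorine, as plain phenyl would show. How an amine or a carboxylic acid on that ring would read is also unknown.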